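The compounds below may be only part of what the source reports. "The series", "measured", "known", "first", "only" and "open" are said of these compounds alone.

In an ADME assay on NCI/ADR-RES cells (Homo sapiens) for inhibition, read by MTT assay, with a stated time of 48 h (a lower number here means a stronger inhibitor, a higher number a weaker inhibitor), compound 1 (`CC(=O)O[C@@H]1C[C@@H](OC(=O)c2ccccc2)/C(C)=C/[C@H]2[C@@H](OC(=O)c3ccccc3)[C@@H](C)[C@H](OC(=O)c3ccc(Br)cc3)[C@]2(OC(C)=O)[C@H](O)[C@](C)(O)/C=C/C1(C)C`) gives > 150000 nM as a limit and not a number. Compound 2 (`CC(=O)O[C@@H]1C[C@@H](OC(=O)c2ccccc2)/C(C)=C/[C@H]2[C@@H](OC(=O)c3ccccc3)[C@@H](C)[C@H](OC(=O)c3cccs3)[C@]2(OC(C)=O)[C@H](O)[C@](C)(O)/C=C/C1(C)C`) gives > 150000 nM and this too is a limit. Compound 2 is therefore known only through the limit of > 150000 nM in this assay, at which 2 of the 2 values shown sit, and has no exact number. Compound 3 (`CC(=O)O[C@@H]1C[C@@H](OC(=O)c2ccccc2)/C(C)=C/[C@H]2[C@@H](OC(=O)c3ccccc3)[C@@H](C)[C@H](OC(=O)c3ccccc3)[C@]2(OC(C)=O)[C@H](O)[C@](C)(O)/C=C/C1(C)C`) differs from compound 2 by phenyl in place of thiophen-2-yl on a carbonyl carbon with phenyl in place of thiophen-2-yl on a carbonyl carbon. Going by the values given here, the only measured step that the two limits leave unreadable from compound 1 to compound 2 has no readable size, so no step beyond the scatter is expected in this assay here. The expected step is a step that the limit leaves unreadable from compound 2 to compound 3 in this estimate. Compound 3 is estimated at 160000 nM with 60000 nM to 300000 nM as its expected range.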

Compound 3, half-maximal inhibitory concentration: 64200 nM
For compound 3 the middle estimate is 2.5-fold (0.40 log units) above the measured one; measured number inside the range.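

In this assay there is an at least 2.3-fold lower number from compound 2 to compound 3 (0.36 log units; beyond the scatter) with phenyl in place of thiophen-2-yl on a carbonyl carbon, so the number at this position does respond to the ring it carries. There is also an at least 2.3-fold lower number from compound 1 to compound 3 (0.36 log units; beyond the scatter) with hydrogen in place of bromo on an aromatic carbon, so this ring is sensitive to what it bears as well. On these data alone, the full size of both steps stays unknown, since compound 1 and compound 2 each give a limit and not a number: the limit of > 150000 nM in this assay, at which 2 of the 3 values shown sit. As far as these compounds go, how an amine or a carboxylic acid on the phenyl ring would read stays open, as does a longer chain in place of that ring.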